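The source may hold more compounds than are shown below. What is called first, only, known or untested is meant among the compounds shown, and "the series" means these compounds.

- Compound 1 `COc1cccc(/C=C/C(=O)/C=C/c2ccc(OCc3cn(CCCCOc4cc(=O)oc5ccccc45)nn3)c(OC)c2)c1` gives 47%
- Compound 2 `COc1cc(/C=C/C(=O)/C=C/c2ccco2)ccc1OCc1cn(CCCCOc2cc(=O)oc3ccccc23)nn1` gives 49%

In a functional assay on THP-1 cells (Homo sapiens) for inhibition, read by sulforhodamine B assay, with a stated time of 48 h, tested at 50 uM (on this read-out higher numbers stand for more inhibition of growth at the one concentration tested and lower numbers for less inhibition of growth), compound 2 reads 49% and sits level with compound 1 within the scatter, so the two cannot be told apart. Compound 3 `COc1ccccc1/C=C/C(=O)/C=C/c1ccc(OCc2cn(CCCCOc3cc(=O)oc4ccccc34)nn2)c(OC)c1` now changes compound 2 in one place: 2-methoxyphenyl in place of furan-2-yl on a double-bonded chain carbon bound to a double-bonded chain carbon. Within the data shown here, only one measured step bears on this, and it concerns the same place: a number 2 percentage points higher from compound 1 to compound 2 (within the scatter). There, furan-2-yl took over from 3-methoxyphenyl and the read-out stayed within the scatter. Neither measured compound carries 2-methoxyphenyl, so this evidence is indirect and the range must stay wide. No shift in either direction beyond the scatter is expected. The expected change is a number 2 percentage points lower from compound 2 to compound 3 (within the scatter). For compound 3 the estimated value is 47%, with an expected range from 36% to 59%.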

Compound 3, percent growth inhibition at one concentration: 40%
Compound 3: the middle estimate sits 7 percentage points above what was measured; the measured number falls inside the stated range.
By their numbers in this assay, from the lowest: compounds 3, 1 and 2 (each within the scatter of the next).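

In this assay, putting 2-methoxyphenyl on a double-bonded chain carbon bound to a double-bonded chain carbon gives a number 9 percentage points lower from compound 2 to compound 3 (within the scatter) and, against the 3-methoxyphenyl group, a number 7 percentage points lower from compound 1 to compound 3 (within the scatter). Among these compounds, this is the first direct reading for 2-methoxyphenyl at this place, and it shows that neither replacing the furan-2-yl ring with this benzene ring nor changing the methoxy group's place on that ring gives a step beyond the usual variation between repeats. Nothing measured here offers an explanation for these readings.

From the compounds shown here alone, all three groups at this place are uncharged aromatic rings, so it remains open whether a carboxylic acid or an amine there would move the number beyond that variation. Going by these compounds, a longer chain at the same place remains equally open.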